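Trimming a methoxy from a pyrrole chalcone

The compounds below may be only part of what the source reports. "The series", "measured", "known", "first", "only" and "open" are said of these compounds alone.

Compound 1 `O=C(/C=C/c1cccc(Cl)c1)c1ccc[nH]1`: 16000 nM
Compound 2 `COc1ccc(/C=C/C(=O)c2ccc[nH]2)c(OC)c1`: 11800 nM
Compound 3 `COc1cccc(/C=C/C(=O)c2ccc[nH]2)c1OC`: 5200 nM

In an assay for inhibition of cytochrome P450 1A1 (Homo sapiens), read by fluorescence, using microsomes, with a stated time of 10 min (on this read-out higher numbers stand for weaker inhibition and lower numbers for stronger inhibition), compound 3 gives 5200 nM, the lowest number of the three, and so the strongest inhibitor of this set. Its nearest neighbour is compound 2, whose number in this assay, 11800 nM, lies beyond the usual scatter above it, and compound 1, with 16000 nM in this assay, is the furthest away. Both of those gaps are therefore real differences, not noise.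

Compound 4 `COc1cccc(/C=C/C(=O)c2ccc[nH]2)c1` keeps the core of compound 3 and differs from it in one place: hydrogen in place of methoxy on an aromatic carbon. For the measured compounds named here, no measured pair shows this exact change, so the expectation rests on the spread among compounds 1 to 3 alone. Compound 3 is the only entry carrying two methoxy groups in this arrangement, and the two compounds lacking it give higher numbers, so a somewhat higher number is expected for compound 4, though perhaps not beyond the scatter. The estimated step is a 1.5-fold higher number from compound 3 to compound 4 (0.19 log units; within the scatter). Compound 4 is expected to give about 8000 nM in this assay, most likely between 3000 nM and 20000 nM.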

Compound 4, half-maximal inhibitory concentration: 6200 nM
Beside the measured number, compound 4's estimate is 1.3-fold (0.11 log units) above it; the range from low to high includes it.
By their numbers in this assay, from the lowest: compounds 3, 4, 2 and 1 (each within the scatter of the next, the first and the last beyond it).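

Taking the methoxy away, with hydrogen in its place on an aromatic carbon ortho to a group of 9 heavy atoms, gives a 1.2-fold higher number from compound 3 to compound 4 (0.08 log units; within the scatter) in this assay, so in this pair that methoxy is not needed to keep the number of compound 3. For the compounds shown here, the remaining methoxy does separate itself from chloro on the same core: the change gives a 2.6-fold lower number from compound 1 to compound 4 (0.41 log units; beyond the scatter), the first single-place step in this set to lie beyond the scatter, though it is modest. Nothing measured here explains either step.

The compounds shown leave open whether hydrogen in place of the remaining methoxy would hold the number of compound 4. They also do not say how an amine, a hydroxyl or an ethoxy chain would fare on the carbon that lost its methoxy.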